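Pyrazin-2-yl in place of methyl: thiol amide notes

The source may hold more compounds than are shown below. What is called first, only, known or untested is meant among the compounds shown, and "the series" means these compounds.

Compound 1 `O=C(NCCCCCCS)c1cc(-c2ccc(-c3ccccc3)cc2)n[nH]1`: > 50000 nM
Compound 2 `Cc1cc(C(=O)NCCCCCCS)[nH]n1`: > 50000 nM

Both entries come from a functional assay on HCT-116 cells (Homo sapiens) for inhibition, read by MTT assay, with a stated time of 96 h (on this read-out lower numbers stand for stronger inhibition of growth and higher numbers for weaker inhibition of growth), and both are limits, not numbers. For the measured compounds named here, compound 2 stands at a limit, > 50000 nM, and so does the whole series so far: the limit of > 50000 nM in this assay, at which 2 of the 2 values shown sit.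

Compound 3 `O=C(NCCCCCCS)c1cc(-c2cnccn2)n[nH]1` follows from compound 2 with pyrazin-2-yl in place of methyl on an aromatic carbon.

Going by the values given here, no measured step exists for this change. In this assay, no step beyond the scatter is expected. This expectation rests on compound 1, whose value is also a limit, > 50000 nM.

The expected step is a number no higher from compound 2 to compound 3 (the limit leaves the size open).

For compound 3 the estimated value is 50000 nM, with an expected range of 20000 nM to 80000 nM.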

Compound 3, concentration for 50% growth inhibition: > 50000 nM
Compound 3: a limit, no number (the forecaster's own chance of this, stated with the estimate: 75%); the middle value sits exactly at the limit.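

In this assay compound 3 gives > 50000 nM, a limit and not a number. For the compounds shown here, compound 2 also sits at a limit, so no step between compound 2 and compound 3 can be read. The compounds shown leave open whether the group on this aromatic carbon affects growth inhibition at all.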